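A Trifluoromethyl Swap Among Inactive Compounds

A few compounds are considered here, and "the series" means these few. Any claim that something is new, unique, unknown or untested is made for them only; others in the source may bear on it.

In a functional assay on CWR22R cells (Homo sapiens) for antiproliferative activity, with a stated time of 96 h (on this read-out higher numbers stand for weaker inhibition and lower numbers for stronger inhibition), compound 1 `Cc1cc(=O)oc2cc(OCC(=O)c3cccc(C(F)(F)F)c3)ccc12` gives > 100000 nM as a limit of the assay, not a number. In this assay compound 2 `O=C(COc1ccc2c(C(F)(F)F)cc(=O)oc2c1)c1cc(C(F)(F)F)cc(C(F)(F)F)c1` is recorded as "not active" (no number reported) with nothing further to compare. In this assay compound 3 `COc1cccc(C(=O)COc2ccc3c(C(F)(F)F)cc(=O)oc3c2)c1` is likewise recorded as "not active" (no number reported) and so has no single number, which leaves it among compounds without a measured potency.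

Compound 4 `O=C(COc1ccc2c(C(F)(F)F)cc(=O)oc2c1)c1cccc(C(F)(F)F)c1` is the next structure to consider. The change is a single swap trifluoromethyl in place of methoxy on an aromatic carbon with trifluoromethyl in place of methoxy on an aromatic carbon. Among the measured compounds shown here, no measured step shows what this swap does, so its size can only be judged from the neighbouring compounds. No step beyond the usual scatter is expected in this assay and activity is expected to stay weak. This expectation rests on compound 2 , recorded as "not active" (no number reported) while also carrying trifluoromethyl on that ring. Compound 4 is estimated at 100000 nM (expected range 20000 nM to 200000 nM).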

Compound 4, half-maximal inhibitory concentration: "not active" (no number reported)
No number was reported for compound 4; no gap can be computed for the estimate.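

Among the compounds shown here, compound 3 and compound 4 are both recorded as "not active" without a number, so no step between them can be read in this assay. The compounds shown leave open whether swapping methoxy for trifluoromethyl changes potency at all, and the only figure they offer is a limit: the limit of > 100000 nM in this assay, at which 1 of the 4 values shown sits.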